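Notes on compound 3: methoxy on the alkyne chain

The source may report more compounds than this note shows. Statements on the series, on what has been measured and on what is new or still open speak of the compounds shown alone.

Going by the values given here, in an ADME assay (liver) for metabolic stability, with Liver microsome (Rattus norvegicus) as the target, using microsomes and NADPH, with a stated time of 30 min, at 37 degrees C, tested at 1 uM (a lower number here means slower removal, a higher number faster removal of the compound), compound 2 `CC#Cc1cc(C(O)(C(F)(F)F)C(F)(F)F)cnc1-c1ccc(S(=O)(=O)c2ccc(N)nc2)cc1` gives 177 mL.min-1.g-1, the only actual number so far. Compound 1 `COc1cc(C(O)(C(F)(F)F)C(F)(F)F)cnc1-c1ccc(S(=O)(=O)c2ccc(N)nc2)cc1` reads < 14 mL.min-1.g-1, which is a limit of the assay and not a number. Among the compounds with values here, the one measured step is an at least 12-fold higher number from compound 1 to compound 2 (1.10 log units; beyond the scatter), with prop-1-yn-1-yl in place of methoxy on an aromatic carbon. Compound 3 `COCC#Cc1cc(C(O)(C(F)(F)F)C(F)(F)F)cnc1-c1ccc(S(=O)(=O)c2ccc(N)nc2)cc1` carries methoxy in place of hydrogen on a saturated chain carbon bound to a triple-bonded carbon, turning prop-1-yn-1-yl into 3-methoxyprop-1-yn-1-yl. The large measured step bears only indirectly, since the triple bond stays in place here. Clearance is therefore expected to stay close to that of compound 2 at 177 mL.min-1.g-1, with no clear shift beyond the scatter. The expected step is a 1.4-fold lower number from compound 2 to compound 3 (0.13 log units; within the scatter). Compound 3 is estimated at 130 mL.min-1.g-1, with an expected range of 55 mL.min-1.g-1 to 300 mL.min-1.g-1.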

Compound 3, intrinsic clearance in microsomes: > 399 mL.min-1.g-1
Compound 3 ended at the assay's limit; the forecaster's own chance of this, stated with the estimate: 5%; at least 3.0-fold (0.48 log units) between middle value and limit.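

In this assay, methoxy in place of hydrogen on a saturated chain carbon bound to a triple-bonded carbon gives an at least 2.2-fold higher number from compound 2 to compound 3 (0.35 log units; beyond the scatter), so the read-out still moves with the triple bond kept in place, which the earlier swap of methoxy for prop-1-yn-1-yl on an aromatic carbon could not show. Measured against methoxy on the aromatic carbon, 3-methoxyprop-1-yn-1-yl gives an at least 28-fold higher number from compound 1 to compound 3 (1.45 log units; beyond the scatter). Compound 3 reads > 399 mL.min-1.g-1, which is a limit of the assay and not a number.

Going by these compounds, how far compound 3 lies from compound 2 stays open. Also open, on these data alone, is whether an amine or a longer chain in place of methoxy on that saturated chain carbon would move this assay in the same direction.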